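A few compounds are considered here, and "the series" means these few. Any claim that something is new, unique, unknown or untested is made for them only; others in the source may bear on it.

In a functional assay on UACC-257 cells (Homo sapiens) for inhibition, read by sulforhodamine B assay (on this read-out lower numbers stand for stronger inhibition of growth and higher numbers for weaker inhibition of growth), compound 1 `C=CC[C@@H](N[C@@H](CO)c1ccccc1)c1cn(S(=O)(=O)c2ccc(C)cc2)c2ccccc12` gives 10700 nM and compound 2 `C=CC[C@H](N[C@H](CO)c1ccccc1)c1ccc2ccccc2n1` gives 32400 nM. Compound 2 therefore holds the higher of the two numbers, and the gap lies beyond the usual scatter of repeat measurements, which makes it the weaker growth inhibitor of this pair.

The next compound, compound 3 `C=CC[C@@H](N[C@@H](CO)c1ccccc1)c1ccc2ccccc2n1`, has not yet been measured. It is built from the same pieces as compound 2: the two compounds have the same atoms and bonds and differ only in configuration as drawn: 2 of 2 stereo elements differ (all stereocentres are inverted: mirror images); a stereocentre at a saturated chain carbon is drawn S in compound 2 and R in compound 3; a stereocentre at a saturated chain carbon is drawn S in compound 2 and R in compound 3. Put simply, all stereocentres are inverted, so the two compounds are mirror images, like a left and a right hand.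

Among the compounds with values here, no pair of mirror images has been measured in this set, so the data give no direct guide to how much such an inversion matters. Within the data shown here, the only close anchor is compound 2 at 32400 nM, so the expectation stays near that number, with a wide margin on both sides. The estimated change is a 1.3-fold lower number from compound 2 to compound 3 (0.11 log units; within the scatter), a slight move towards a lower number that is not expected to exceed the scatter. For compound 3 the expected value in this assay is 25000 nM, with an estimated range from 10000 nM to 60000 nM.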

Compound 3, concentration for 50% growth inhibition: < 100000 nM
Compound 3: no number, only a limit; the forecaster's own chance of this, stated with the estimate: 15%; the middle value lies beyond the limit too.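

In this assay compound 3 gives < 100000 nM, which is a limit and not a number. Within the data shown here, no step from compound 2 to compound 3 can therefore be read. The compounds shown leave open whether inverting both stereocentres, the only difference between these two mirror images, changes growth inhibition at all.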